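The source may hold more compounds than are shown below. What is called first, only, known or untested is meant among the compounds shown, and "the series" means these compounds.

Compound 2 `COC(=O)c1cc(-c2cccc(NC(=O)c3ccc(/C=C/C(=O)c4cccc(Cl)c4)cc3)c2)on1` carries the shared core with a 3-chlorophenyl on a carbonyl carbon. In an ADME assay on Vero cells (Chlorocebus sabaeus) for cytotoxicity, read by MTT assay, with a stated time of 72 h (on this read-out higher numbers stand for lower toxicity in this test and lower numbers for higher toxicity in this test), compound 2 gives > 2.5 ug/mL, which is a limit of the assay and not a number. Compound 1 `COC(=O)c1cc(-c2cccc(NC(=O)c3ccc(/C=C/C(=O)c4ccc(Br)cc4)cc3)c2)on1` differs from it only by a 4-bromophenyl on that carbonyl carbon. In this assay compound 1 gives > 20 ug/mL, again a limit rather than a number. The step that the two limits leave unreadable from compound 1 to compound 2 therefore has no readable size or direction, because one value sits at the limit of > 2.5 ug/mL in this assay, at which 1 of the 2 values shown sits, and the other at the limit of > 20 ug/mL in this assay, at which 1 of the 2 values shown sits. Compound 3 `COC(=O)c1cc(-c2cccc(NC(=O)c3ccc(/C=C/C(=O)c4ccccc4C)cc3)c2)on1` is the unmeasured member: 2-methylphenyl in place of 3-chlorophenyl on a carbonyl carbon. Among the measured compounds shown here, the only measured step bearing on this position is the one from compound 1 to compound 2, and it yields no size, so no direction can be drawn from it for this assay. With both neighbours at limits, compound 3 is expected to come out at 20 ug/mL, within 5 ug/mL to 60 ug/mL, and the expected step that the limit leaves unreadable from compound 2 to compound 3 is taken as one that need not exceed the scatter.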

Compound 3, half-maximal cytotoxic concentration: > 25 ug/mL
Compound 3 ended at the assay's limit (the forecaster's own chance of this, stated with the estimate: 70%); middle value at least 1.2-fold (0.09 log units) from the limit.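

In this assay compound 3 gives > 25 ug/mL, which is a limit of the assay and not a number. Among the compounds shown here, with compound 1, compound 2 and compound 3 all at limits, no step among them can be read. The compounds shown leave open whether 4-bromophenyl, 3-chlorophenyl or 2-methylphenyl on the carbonyl carbon changes the half-maximal cytotoxic concentration at all, and in which direction.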